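Swapping the aryl group on a urea-linked pyrazine series

The source may report more compounds than this note shows. Statements on the series, on what has been measured and on what is new or still open speak of the compounds shown alone.

Of the compounds shown here, three share one core and have been tested in a functional assay on HepG2 cells (Homo sapiens) for antiproliferative activity, read by MTT assay, with a stated time of 48 h; a higher number here means a weaker inhibitor, a lower number a stronger inhibitor. Compound 1 `O=C(Nc1cccc(CNc2nccnc2Cl)c1)NC1CCCCC1` carries a cyclohexyl group on one urea nitrogen; in this assay compound 1 reaches only the assay limit of > 40000 nM. Compound 2 `O=C(Nc1ccc(Cl)cc1)Nc1cccc(CNc2nccnc2Cl)c1` replaces that group with a 4-chlorophenyl and gives 8350 nM; the change is an at least 4.7-fold lower number from compound 1 to compound 2 (0.68 log units; beyond the scatter). Compound 3 `CC(C)(C)c1ccc(NC(=O)Nc2cccc(CNc3nccnc3Cl)c2)cc1` gives 7550 nM, and the step of a 1.1-fold lower number from compound 2 to compound 3 (0.04 log units; within the scatter) stays within the scatter, so compound 2 and compound 3 stand together. Compound 1 is represented only by a limit (the limit of > 40000 nM in this assay, at which 1 of the 3 values shown sits).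

Compound 4 `CCc1ccccc1NC(=O)Nc1cccc(CNc2nccnc2Cl)c1` differs from compound 2 by 2-ethylphenyl in place of 4-chlorophenyl on an amide-type nitrogen. Both measured steps bear on this: moving from a saturated ring to an aryl ring gave a modest gain, while exchanging one aryl substituent for another changed nothing beyond the scatter. Since compound 4 keeps an aryl ring and only alters its substituent, the expected step of a 1.0-fold lower number from compound 2 to compound 4 (0.02 log units; within the scatter) is no larger than the scatter. Compound 4 is therefore estimated at 8000 nM, with a range from 3000 nM to 25000 nM.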

Compound 4, half-maximal inhibitory concentration: 7860 nM
Estimate against measurement, compound 4: 1.0-fold (0.01 log units) above; measured number inside the range.
By their numbers in this assay, from the lowest: compounds 3, 4 and 2 (each within the scatter of the next). At a limit, above all of these: compound 1.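

Compound 4 adds a third aryl group to the comparison. In this assay, 2-ethylphenyl in place of 4-chlorophenyl gives a 1.1-fold lower number from compound 2 to compound 4 (0.03 log units; within the scatter), so on this amide-type nitrogen compounds 2, 3 and 4 stand together even though the aryl substituent differs in each. 2-Ethylphenyl in place of cyclohexyl gives an at least 5.0-fold lower number from compound 1 to compound 4 (0.70 log units; beyond the scatter), so the gap first seen with 4-chlorophenyl appears again with a different aryl group, and it separates the cyclohexyl compound from the aryl compounds shown. Compound 1 stands only at a limit: the limit of > 40000 nM in this assay, at which 1 of the 4 values shown sits.

The compounds shown leave open whether any group on this nitrogen can give a number clearly lower than these three aryl ureas. Going by these compounds, what a phenyl ring bearing a carboxylic acid or an amine, or an open alkyl chain in place of the ring, would do here remains unknown.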